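Replacing cyclopentyl with isopropyl on the shared core

A few compounds are considered here, and "the series" means these few. Any claim that something is new, unique, unknown or untested is made for them only; others in the source may bear on it.

Of the compounds shown here, two have been measured in a functional assay on NCI-H460 cells (Homo sapiens) for antiproliferative activity, read by CCK-8 assay, with a stated time of 72 h, tested at 2 uM; a lower number here means a weaker effect, a higher number a stronger effect of the compound at the concentration tested. Compound 1 `Cc1ccc(Nc2nc(Cl)nc3c2ncn3Cc2ccc(/C=C/C(=O)Nc3ccccc3N)cc2)cc1` gives 31.3% in this assay. Compound 2 `Nc1ccccc1NC(=O)/C=C/c1ccc(COCNc2nc(Nc3cccc(Cl)c3)c3ncn(C4CCCC4)c3n2)cc1` gives 37.1% in this assay, the highest of the two numbers, with compound 1 standing a few points lower, a difference within the scatter, so no order between the two can be stated. Among the measured compounds shown here, no step between compounds that differ in one place has been measured, so nothing in the data tells how large a single change on this core moves the inhibition.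

Compound 3 `CC(C)n1cnc2c(Nc3cccc(Cl)c3)nc(NCOCc3ccc(/C=C/C(=O)Nc4ccccc4N)cc3)nc21` has not been measured. It differs from compound 2 in one place: isopropyl in place of cyclopentyl on an aromatic nitrogen. The change swaps one saturated hydrocarbon group for a smaller one on the aromatic nitrogen, with no change in donor or acceptor count. For the measured compounds named here, with no measured step to rest on, the expected step of a number 4.1 percentage points lower from compound 2 to compound 3 (within the scatter) is small, no larger than the scatter, in either direction. The inhibition of compound 3 is therefore estimated at 33%, with a range from 20% to 48%.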

Compound 3, a percentage reported as inhibition, at one concentration (the size of the read-out at that concentration, not a potency): 53%
For compound 3 the middle estimate is 20 percentage points below the measured one; measured number above the stated range.
By their numbers in this assay, from the lowest: compounds 1 and 2 (each within the scatter of the next); then compound 3.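

In this assay, the substituent on the aromatic nitrogen now has its first measured step, a number 15.9 percentage points higher from compound 2 to compound 3 (beyond the scatter), which shows that inhibition on this core is sensitive to the group at this place. The change replaces cyclopentyl, with 5 heavy atoms and one ring, with isopropyl, with 3 heavy atoms and no ring, and neither group has any hydrogen-bond donors or acceptors, so this step involves only a swap between two hydrocarbon groups. Nothing in the available data explains why inhibition rises with this swap.

On these data alone, a single step cannot separate the loss of the ring from the loss of carbon atoms, so it remains open whether cyclopropyl, which keeps a ring, would behave like cyclopentyl or like isopropyl on the same nitrogen. As far as these compounds go, it is also open whether ethyl or methyl there would extend the rise or reverse it, and whether a group carrying an amine or a carboxylic acid would be tolerated at this place.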